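Chloro in place of isopropyl on a urea series

This account rests on a few compounds, and the source may have more. Where it says the series, first, only, none or still open, it means among the compounds named here.

Measured compounds and their values in an ADME assay on the whole organism with Oryza sativa as the target, tested at 0.1 uM; on this read-out higher numbers stand for a weaker effect at the one concentration tested and lower numbers for a stronger effect: compound 1 `CC(C)c1cccc(NC(=O)N[C@H](C)c2ccccc2)c1` gives 74%; compound 2 `CC(C)c1cccc(NC(=O)N[C@@H](C)c2ccccc2)c1` gives 95%; compound 3 `C[C@H](NC(=O)Nc1ccc(C(F)(F)F)cc1)c1ccccc1` gives 94%.

Compound 1 stands lowest of the three numbers, with compound 3 nearest and compound 2 furthest, both beyond the scatter. Among the measured compounds shown here, the one measured step, a number 21 percentage points higher from compound 1 to compound 2 (beyond the scatter), rests on the fact that compounds 1 and 2 differ only in the configuration as drawn alone; compounds 2 and 3 carry different aryl substituents but their two values stand together within the scatter.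

Compound 4 `C[C@@H](NC(=O)Nc1cccc(Cl)c1)c1ccccc1` keeps the configuration as drawn of compound 1 and differs from it in one place: chloro in place of isopropyl on an aromatic carbon. For the measured compounds named here, no measured step touches this kind of change, since the only step concerns configuration, so it gives no guide to size or direction. The expectation therefore leans on the values of compounds 2 and 3 as the more common level and on the value of compound 1 as the starting point. Compound 4 is expected to give 82%, between 64% and 98%, an estimated step of a number 8 percentage points higher from compound 1 to compound 4 (within the scatter) that may not exceed the scatter.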

Compound 4, a percentage reported as activity, at one concentration (the size of the read-out at that concentration, not a potency): 97%
Compound 4: the middle estimate sits 15 percentage points below what was measured, within the range that was stated.
By their numbers in this assay, from the lowest: compound 1; then compounds 3, 2 and 4 (each within the scatter of the next).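

In this assay, chloro in place of isopropyl on the aromatic carbon gives a number 23 percentage points higher from compound 1 to compound 4 (beyond the scatter), so the read-out is not indifferent to the group at this position. The low number of compound 1 now gives way under either of two single changes, and the change of configuration alone likewise gives a number 21 percentage points higher from compound 1 to compound 2 (beyond the scatter). Nothing on hand accounts for the step to chloro.

Going by these compounds, one replacement cannot separate the loss of isopropyl from the arrival of chloro, so it stays open which of the two matters. A methyl, a tert-butyl or a methoxy group at this position could show whether a number like that of compound 1 returns, and compound 4 alone does not tell how chloro behaves with the opposite configuration.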